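Replacing the urea of compound 3 with a benzamide

The source may hold more compounds than are shown below. What is called first, only, known or untested is meant among the compounds shown, and "the series" means these compounds.

Measured compounds:
- compound 1, `COc1cc(-c2nn(-c3cccc(NC(=O)Nc4ccc(Cl)c(Cl)c4)c3)cc2-c2ccncc2)ccc1Cl`: 150 nM
- compound 2, `COc1cc(-c2nn(-c3cccc(NC(=O)Nc4cccc(C(F)(F)F)c4)c3)cc2-c2ccncc2)ccc1Cl`: 560 nM
- compound 3, `COc1cc(-c2nn(-c3cccc(NC(=O)Nc4ccc(Cl)c(C(F)(F)F)c4)c3)cc2-c2ccncc2)ccc1Cl`: 500 nM

Three compounds share one core and differ only in the aryl group carried on the urea. In a functional assay on HOP-92 cells (Homo sapiens) for inhibition, read by sulforhodamine B assay, with a stated time of 48 h (on this read-out higher numbers stand for weaker inhibition and lower numbers for stronger inhibition), compound 1 gives 150 nM, compound 2 gives 560 nM and compound 3 gives 500 nM. Compound 3 stands second highest of the three numbers; it lies within the scatter of compound 2 and is set apart only from compound 1, as the step of a 3.3-fold higher number from compound 1 to compound 3 (0.52 log units; beyond the scatter) shows. The other two steps, a 3.7-fold higher number from compound 1 to compound 2 (0.57 log units; beyond the scatter) and a 1.1-fold lower number from compound 2 to compound 3 (0.05 log units; within the scatter), are likewise modest or within the scatter.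

Compound 4, `COc1cc(-c2nn(-c3cccc(NC(=O)c4ccccc4)c3)cc2-c2ccncc2)ccc1Cl`, is not yet measured. It differs from compound 3 by phenyl in place of (4-chloro-3-(trifluoromethyl)phenyl)amino on a carbonyl carbon. Among the measured compounds shown here, none of the measured steps bears directly on this change: all three exchange one aryl group on the urea for another, whereas here the urea itself is cut back to a benzamide with no substituents on its ring. Since the aryl variations already moved this assay by modest amounts, and the whole aryl-urea arm is now removed, a larger loss is expected, though with wide uncertainty. Compound 4 is therefore estimated at 2500 nM (range 500 nM to 12000 nM), a step of a 5.0-fold higher number from compound 3 to compound 4 (0.70 log units; beyond the scatter) expected from compound 3 to compound 4.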

Compound 4, half-maximal inhibitory concentration: 320 nM
Compound 4: middle estimate off by 7.8-fold (0.89 log units), on the high side; measured number outside the range, below it.
By their numbers in this assay, from the lowest: compound 1; then compounds 4, 3 and 2 (each within the scatter of the next).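

In this assay, the (4-chloro-3-(trifluoromethyl)phenyl)amino group on the carbonyl carbon can give way to phenyl with no change beyond the scatter, as a 1.6-fold lower number from compound 3 to compound 4 (0.19 log units; within the scatter) shows, and the same holds for the (3-(trifluoromethyl)phenyl)amino group, with a 1.8-fold lower number from compound 2 to compound 4 (0.24 log units; within the scatter). Among the compounds shown, then, the substituted aryl-urea arm as a whole is not required for a number in this range, and only the (3,4-dichlorophenyl)amino group sets a urea apart from the plain benzamide, by the modest 2.1-fold higher number from compound 1 to compound 4 (0.33 log units; beyond the scatter). No measurement among the data given accounts for this result.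

The compounds shown leave open whether chloro or trifluoromethyl on the phenyl ring of the benzamide would give the same modest separation that the 3,4-dichloro pattern gives on the urea. Going by these compounds, they also leave open what happens when the phenyl on the carbonyl carbon is replaced by a methyl, a longer alkyl chain or a morpholine, so how much of that ring this position needs remains unknown.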